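The source may report more compounds than this note shows. Statements on the series, on what has been measured and on what is new or still open speak of the compounds shown alone.

Measured so far in a functional assay on DU-145 cells (Homo sapiens) for inhibition, read by trypan blue exclusion, with a stated time of 96 h; on this read-out higher numbers stand for weaker inhibition of growth and lower numbers for stronger inhibition of growth:
- compound 1 `Cc1ccc(CS(=O)(=O)/C(=C/c2ccc(Br)cc2)C(=O)c2ccc(Cl)cc2)cc1`: 25000 nM
- compound 2 `COc1ccccc1/C=C(\C(=O)c1ccc(Cl)cc1)S(=O)(=O)Cc1ccc(C)cc1`: 10000 nM
- compound 3 `Cc1ccc(CS(=O)(=O)/C(=C/c2sccc2C)C(=O)c2ccc(Cl)cc2)cc1`: 25000 nM

Compound 3 stands level with compound 1, and the two share the highest of the three numbers: no change at the digits printed from compound 1 to compound 3 (within the scatter). Compound 2 holds the lowest number: a 2.5-fold lower number from compound 1 to compound 2 (0.40 log units; beyond the scatter), and a 2.5-fold higher number from compound 2 to compound 3 (0.40 log units; beyond the scatter).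

Next is compound 4 `Cc1ccc(CS(=O)(=O)/C(=C/c2ccccc2Br)C(=O)c2ccc(Cl)cc2)cc1`, with the change (2-bromophenyl in place of 3-methylthiophen-2-yl on a double-bonded chain carbon bound to a double-bonded chain carbon). This places 2-bromophenyl in place of 3-methylthiophen-2-yl on a double-bonded chain carbon bound to a double-bonded chain carbon. Within the data shown here, no measured step covers this exchange directly, so the three steps above serve only as guides. The entering group shares its bromine with the 4-bromophenyl of compound 1, which gives 25000 nM. It shares the number in its name with the 2-methoxyphenyl of compound 2, which gives 10000 nM. Three compounds cannot show which resemblance counts, so a value between these two is expected. In this assay the expected change is small and toward a lower number: a 1.7-fold lower number from compound 3 to compound 4 (0.22 log units; within the scatter). For compound 4 the estimated value is 15000 nM. The expected range for compound 4 runs from 6000 nM to 35000 nM.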

Compound 4, concentration for 50% growth inhibition: 25000 nM
The estimate for compound 4 lay 1.7-fold (0.22 log units) below the measured number, and the stated range covers the measured number.
By their numbers in this assay, from the lowest: compound 2; then compounds 1, 3 and 4 (each within the scatter of the next).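

In this assay, among these compounds, the bromine's place on the phenyl ring at this double-bonded chain carbon makes no readable difference between these two isomers (no change at the digits printed from compound 1 to compound 4 (within the scatter)), which the earlier compounds could not show. Among the compounds shown here, compound 2 and compound 4 give the first exchange confined to a single ring substituent on an aromatic carbon (a 2.5-fold higher number from compound 2 to compound 4 (0.40 log units; beyond the scatter)), so the lower number of compound 2 follows its methoxy rather than the mere presence of a group named at the 2 position of the ring. The five-membered ring also reads alike with the 2-bromophenyl (no change at the digits printed from compound 3 to compound 4 (within the scatter)), which leaves compound 2 alone apart from the other three, and no supporting data are on hand to account for any of these readings.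

Going by these compounds, whether a substituent other than methoxy, such as an amine or a carboxylic acid, on the same phenyl ring would move the number further remains open. On these data alone, all four compounds also share the rest of the core, so it is unknown whether the exchange of methoxy for bromo gives the same step when other groups stand elsewhere on it.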